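Cytotoxicity at the limit and an isobutyl swap

The compounds below may be only part of what the source reports. "The series", "measured", "known", "first", "only" and "open" are said of these compounds alone.

Compound 1 `CC(C)Cc1csc2nc(C(=O)N3CCN(C4CCCC4)C(=O)C3)c(Cl)n12`: > 10000 nM (a limit)
Compound 2 `O=C(c1nc2sc(Cl)c(C3CC3)n2c1Cl)N1CCN(C2CCCC2)C(=O)C1`: > 10000 nM (a limit)

Of the compounds shown here, two have so far been tested in an ADME assay on Huh-7 cells (Homo sapiens) for cytotoxicity; on this read-out higher numbers stand for lower toxicity in this test and lower numbers for higher toxicity in this test. In this test, compound 2 gives > 10000 nM, which is a limit of the assay and not a number. Compound 1 gives > 10000 nM, which is likewise a limit. Taken together, the measurements show (the limit of > 10000 nM in this assay, at which 2 of the 2 values shown sit), so neither compound can be ranked against the other.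

Compound 3 `CC(C)Cc1c(Cl)sc2nc(C(=O)N3CCN(C4CCCC4)C(=O)C3)c(Cl)n12` has not yet been measured. It departs from compound 2 in one place: isobutyl in place of cyclopropyl on an aromatic carbon. Isobutyl stands in place of cyclopropyl on an aromatic carbon of a five-membered aromatic ring with one nitrogen and one sulfur, next to the ring atom that bears a chloro group.

For the measured compounds named here, no measured step shows what such an exchange does in this assay. The expectation therefore rests on compound 2, whose limit is > 10000 nM. No change beyond the usual scatter is expected, and the estimated step is a step that the limit leaves unreadable from compound 2 to compound 3. Compound 3 is expected at 12000 nM, with an estimated range from 5000 nM to 25000 nM.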

Compound 3, half-maximal cytotoxic concentration: > 10000 nM
Compound 3 gave a limit, no number (the forecaster's own chance of this, stated with the estimate: 80%); the middle value lies beyond the limit too.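

In this assay compound 3 also gives only a limit, so neither the isobutyl swap from compound 2 nor the chloro in place of hydrogen from compound 1 can be read as a step: the limit of > 10000 nM in this assay, at which 3 of the 3 values shown sit.

The compounds shown leave open at what concentration, if any, these three would become toxic to the cells.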